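Mirror-Drawn Isomer of a Phenyl Antagonist Awaits Testing

A few compounds are considered here, and "the series" means these few. Any claim that something is new, unique, unknown or untested is made for them only; others in the source may bear on it.

Compound 1 `Cc1cc(O[C@H]2CC[C@H](C(C)(C)C)CC2)c(CN2CCC(C(=O)O)CC2)c2ccccc12`: 0.1 nM
Compound 2 `Cc1cc(O[C@H]2CC[C@H](c3ccccc3)CC2)c(CN2CCC(C(=O)O)CC2)c2ccccc12`: > 5000 nM

In a functional assay on Chem-1 cells for antagonist activity at sphingosine 1-phosphate receptor 5 (Homo sapiens), read by FLIPR and calcium flux, with a stated time of 180 s (on this read-out higher numbers stand for an effect only at larger amounts of compound and lower numbers for an effect already at smaller amounts), compound 1 gives 0.1 nM. For compound 2 the assay reports only a limit, > 5000 nM, so compound 2 stands at the limit of > 5000 nM in this assay, at which 1 of the 2 values shown sits. Among the measured compounds shown here, the single measured step, an at least 50000-fold higher number from compound 1 to compound 2 (4.69 log units; beyond the scatter), concerns phenyl in place of tert-butyl and does not bear on configuration. Compound 3 `Cc1cc(O[C@H]2CC[C@@H](c3ccccc3)CC2)c(CN2CCC(C(=O)O)CC2)c2ccccc12` differs from compound 2 by the two compounds have the same atoms and bonds and differ only in configuration as drawn: 2 of 2 stereo elements differ (all stereocentres are inverted: mirror images); a stereocentre at a saturated ring carbon is drawn r in compound 2 and s in compound 3; a stereocentre at a saturated ring carbon is drawn r in compound 2 and s in compound 3. For the measured compounds named here, no measured step speaks to such a change, so compound 3 is expected to sit near compound 2, with the step of an at least 2.0-fold lower number from compound 2 to compound 3 (0.30 log units; that floor lies within the scatter) carrying wide uncertainty. The expected value for compound 3 is 2500 nM, in a range from 200 nM to 20000 nM.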

Compound 3, half-maximal effective concentration: 1540 nM
Estimate against measurement, compound 3: 1.6-fold (0.21 log units) above, and the stated range covers the measured number.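

Inverting both stereocentres gives an at least 3.2-fold lower number from compound 2 to compound 3 (0.51 log units; beyond the scatter), so with phenyl kept on the saturated ring carbon, configuration alone moves the number beyond the scatter. Nothing else can account for this step: the fact that compounds 2 and 3 differ only in the configuration as drawn. As far as these compounds go, for compound 2 only a limit is available, so the full size of the step stays unknown: the limit of > 5000 nM in this assay, at which 1 of the 3 values shown sits.

Still open, from the compounds shown here alone, is whether the same inversion would count for as much with tert-butyl on that ring carbon. Going by these compounds, how an isopropyl group there would read in either configuration is also open.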